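This account rests on a few compounds, and the source may have more. Where it says the series, first, only, none or still open, it means among the compounds named here.

Three compounds have been measured in a functional assay on HeLa cells (Homo sapiens) for antiproliferative activity, read by MTT assay, with a stated time of 72 h; a higher number here means a weaker inhibitor, a lower number a stronger inhibitor:

compound 1, `COc1ncc(-c2ccc3c(c2)N(c2ccc(C)cc2)C(=O)CO3)cc1NS(=O)(=O)c1ccc(F)cc1`, gives 4650 nM.
compound 2, `COc1ccc(N2C(=O)COc3ccc(-c4cnc(OC)c(NS(=O)(=O)c5ccc(F)cc5)c4)cc32)cc1`, gives 1220 nM.
compound 3, `O=C1COc2ccc(-c3cnc(Cl)c(NS(=O)(=O)c4ccc(F)cc4)c3)cc2N1c1ccc(F)cc1`, gives only a limit of the assay, > 40000 nM.

Within the data shown here, compound 3 therefore stands apart from the other two: its value is not a number but the limit (the limit of > 40000 nM in this assay, at which 1 of the 3 values shown sits), and it is the one chloro compound among the three. Compound 4, `COc1ncc(-c2ccc3c(c2)N(c2ccc(F)cc2)C(=O)CO3)cc1NS(=O)(=O)c1ccc(F)cc1`, differs from compound 3 in one place: methoxy in place of chloro on an aromatic carbon. Among the measured compounds shown here, no measured step covers this change. For the measured compounds named here, the one measured step, a 3.8-fold lower number from compound 1 to compound 2 (0.58 log units; beyond the scatter), concerns a different position on the shared core and gives no direct guidance on the chloro-to-methoxy exchange. What the data do show is that both methoxy compounds, compound 1 with 4650 nM and compound 2 with 1220 nM, return numbers in this assay, whereas compound 3 does not. Compound 4 carries the methoxy group of compounds 1 and 2 on the remainder of compound 3, so a number rather than a limit is expected, though its size is uncertain. Compound 4 is estimated at 5000 nM, between 1500 nM and 20000 nM, which means an expected step of an at least 8.0-fold lower number from compound 3 to compound 4 (0.90 log units; beyond the scatter).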

Compound 4, half-maximal inhibitory concentration: 10500 nM
For compound 4 the middle estimate is 2.1-fold (0.32 log units) below the measured one; measured number inside the range.
By their numbers in this assay, from the lowest: compound 2; then compound 1; then compound 4. At a limit, above all of these: compound 3.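

In this assay, among these compounds, methoxy in place of chloro on the aromatic carbon next to the ring nitrogen, ortho to the ((4-fluorophenyl)sulfonyl)amino group, gives the first direct reading of this change: an at least 3.8-fold lower number from compound 3 to compound 4 (0.58 log units; beyond the scatter). Compound 3 holds a limit and not a number, so this step marks only a bound on the size of the change: the limit of > 40000 nM in this assay, at which 1 of the 4 values shown sits. With this methoxy kept in place, the group on the other aromatic ring also moves the number, since fluoro in place of methoxy gives an 8.6-fold higher number from compound 2 to compound 4 (0.93 log units; beyond the scatter), and fluoro in place of methyl gives a 2.3-fold higher number from compound 1 to compound 4 (0.35 log units; beyond the scatter).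

On these data alone, whether the change depends on methoxy itself stays open, and an amine, a hydroxyl or a longer chain such as ethoxy at this position would be needed to settle it. As far as these compounds go, the chloro-to-methoxy change is also read here only with fluoro on the other aromatic ring, so its size alongside the methyl of compound 1 or the methoxy of compound 2 remains unknown.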